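The source may report more compounds than this note shows. Statements on the series, on what has been measured and on what is new or still open speak of the compounds shown alone.

Measured compounds:
compound 1 `Cn1cc(-c2cc(C(O)(C(F)(F)F)C(F)(F)F)cnc2N2CCN(S(=O)(=O)c3ccc(N)nc3)CC2)cn1`: 19 mL.min-1.g-1
compound 2 `CC(C)(C)n1cc(-c2cc(C(O)(C(F)(F)F)C(F)(F)F)cnc2N2CCN(S(=O)(=O)c3ccc(N)nc3)CC2)cn1`: 86 mL.min-1.g-1
compound 3 `COc1ccc(-c2cc(C(O)(C(F)(F)F)C(F)(F)F)cnc2N2CCN(S(=O)(=O)c3ccc(N)nc3)CC2)cn1`: 25 mL.min-1.g-1

In an ADME assay (liver) for metabolic stability, with Liver microsome (Homo sapiens) as the target, using microsomes and NADPH, with a stated time of 30 min, tested at 1 uM (on this read-out higher numbers stand for fast clearance and lower numbers for slow clearance), compound 1 gives the lowest of the three numbers. Compound 3 sits nearest, a 1.3-fold higher number from compound 1 to compound 3 (0.12 log units; within the scatter), and compound 2 lies furthest away, a 4.5-fold higher number from compound 1 to compound 2 (0.66 log units; beyond the scatter). Compound 4 `Nc1ccc(S(=O)(=O)N2CCN(c3ncc(C(O)(C(F)(F)F)C(F)(F)F)cc3-c3ccc4ocnc4c3)CC2)cn1` has not yet been measured. It differs from compound 1 in one place: 1,3-benzoxazol-5-yl in place of 1-methyl-1H-pyrazol-4-yl on an aromatic carbon. Going by the values given here, two measured steps bear on this. Exchanging one aromatic group for another on that carbon, as in compound 3, stayed within the scatter, whereas the tert-butyl in place of methyl, as in compound 2, raised the number modestly. The change to compound 4 is therefore expected to give a small to modest rise, a 1.8-fold higher number from compound 1 to compound 4 (0.27 log units; within the scatter). Compound 4 is estimated at 35 mL.min-1.g-1, within 15 mL.min-1.g-1 to 80 mL.min-1.g-1.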

Compound 4, intrinsic clearance in microsomes: < 14 mL.min-1.g-1
Compound 4 ended at the assay's limit (the forecaster's own chance of this, stated with the estimate: 5%); middle value at least 2.5-fold (0.39 log units) from the limit.
By their numbers in this assay, from the lowest: compounds 1 and 3 (each within the scatter of the next); then compound 2. At a limit, below all of these: compound 4.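

In this assay, compound 4 ends at a limit of the assay, not at a number: the limit of < 14 mL.min-1.g-1 in this assay, at which 1 of the 4 values shown sits. On this aromatic carbon, the larger 1,3-benzoxazol-5-yl brings no rise in the number, with an at least 1.3-fold lower number from compound 1 to compound 4 (0.13 log units; that floor lies within the scatter) and an at least 1.7-fold lower number from compound 3 to compound 4 (0.25 log units; that floor lies within the scatter). The clear step is an at least 6.1-fold lower number from compound 2 to compound 4 (0.78 log units; beyond the scatter), so among these compounds a larger group here need not mean a higher number.

On these data alone, how far the true value of compound 4 lies under its limit stays open. Also open, as far as these compounds go, is whether a small amine or a carboxylic acid on this carbon would keep the number as low.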